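The source may hold more compounds than are shown below. What is called first, only, known or untested is meant among the compounds shown, and "the series" means these compounds.

Values in an ADME assay on MT4 cells (Homo sapiens) for cytotoxicity, read by MTT assay, with a stated time of 5 days; a lower number here means that less compound is tolerated, a higher number that more compound is tolerated:

Compound 1 `Cc1cc(C)cc(S(=O)(=O)c2c(C(=O)N[C@@H]3CCN(Cc4cccnc4)C3)[nH]c3ccc(Cl)cc23)c1`: 36500 nM
Compound 2 `Cc1cc(C)cc(S(=O)(=O)c2c(C(=O)N[C@H]3CCN(S(C)(=O)=O)C3)[nH]c3ccc(Cl)cc23)c1`: 29900 nM
Compound 3 `Cc1cc(C)cc(S(=O)(=O)c2c(C(=O)NS(=O)(=O)c3ccc(F)cc3)[nH]c3ccc(Cl)cc23)c1`: > 252000 nM (a limit, not a number)

Compound 3 stands at a limit of this assay and has no exact number. Its entry is the limit of > 252000 nM in this assay, at which 1 of the 3 values shown sits.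

Compound 4 `Cc1cc(C)cc(S(=O)(=O)c2c(C(=O)NS(=O)(=O)c3ccccc3)[nH]c3ccc(Cl)cc23)c1` has hydrogen in place of fluoro on an aromatic carbon, para to a large group: hydrogen in place of fluoro on an aromatic carbon. The phenylsulfonyl part stays, so 4-fluorophenyl simply becomes phenyl.

Going by the values given here, no measured step isolates this change. The nearest evidence comes from replacing the whole group on the amide-type nitrogen. Two such replacements end in the (4-fluorophenyl)sulfonyl group: an at least 6.9-fold higher number from compound 1 to compound 3 (0.83 log units; beyond the scatter) and an at least 8.4-fold higher number from compound 2 to compound 3 (0.92 log units; beyond the scatter). Both lie beyond the scatter, while the replacement that does not involve this group, a 1.2-fold lower number from compound 1 to compound 2 (0.09 log units; within the scatter), stays within it. These steps are far larger in structural terms than the loss of one fluoro, and they give only indirect guidance. With the phenylsulfonyl part retained, no shift beyond the scatter is expected in this assay, and a report as a limit is likely.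

The expected step is a number no higher from compound 3 to compound 4 (the limit leaves the size open).

For compound 4 the estimate is 250000 nM, with an expected range of 100000 nM to 320000 nM.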

Compound 4, half-maximal cytotoxic concentration: 167000 nM
The estimate for compound 4 lay 1.5-fold (0.18 log units) above the measured number, and the stated range covers the measured number.
By their numbers in this assay, from the lowest: compounds 2 and 1 (each within the scatter of the next); then compound 4. At a limit, above all of these: compound 3.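

In this assay, the phenylsulfonyl group on the amide-type nitrogen now has an exact number, so the gap to the two pyrrolidin-3-yl compounds can be sized rather than bounded: a 5.6-fold higher number from compound 2 to compound 4 (0.75 log units; beyond the scatter) and a 4.6-fold higher number from compound 1 to compound 4 (0.66 log units; beyond the scatter). Both steps lie beyond the scatter, which shows that the separation from those compounds persists without the fluoro on the aromatic carbon, para to a large group. From the compounds shown here alone, for hydrogen in place of fluoro itself, the reading is only a floor within the scatter, so no real effect of this change can be claimed from it, and its true size remains unknown: an at least 1.5-fold lower number from compound 3 to compound 4 (0.17 log units; that floor lies within the scatter). Compound 3 remains a limit and not a number: the limit of > 252000 nM in this assay, at which 1 of the 4 values shown sits.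

Going by these compounds, it remains open whether the higher tolerance in this assay follows the sulfonyl group on the amide-type nitrogen or the phenyl ring attached to it, as a methylsulfonyl group at that nitrogen would help to separate the two. On these data alone, how an amine, a methoxy group or a carboxylic acid in place of the fluoro would read is also open.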